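The compounds below may be only part of what the source reports. "The series", "measured", "known", "first", "only" and "open" are said of these compounds alone.

Of the compounds shown here, three sharing one core have been measured in an ADME assay on Huh-7 cells (Homo sapiens) for cytotoxicity; on this read-out higher numbers stand for weaker inhibition and lower numbers for stronger inhibition. Compound 1 `CN(c1cc2ncc(=O)[nH]c2cc1NC(=S)NC(=O)/C=C/c1ccccc1)C1CCCCC1` gives 11000 nM, compound 2 `CN(c1cc2ncc(=O)[nH]c2cc1NC(=N)NCc1ccc(F)cc1)C1CCCCC1` gives 10200 nM, and compound 3 `CN(c1cc2ncc(=O)[nH]c2cc1NC(=N)NCc1ccc(Cl)cc1)C1CCCCC1` gives 4400 nM, the lowest of the three numbers. For the measured compounds named here, the only step between compounds that differ in one place, a 2.3-fold lower number from compound 2 to compound 3 (0.37 log units; beyond the scatter), came from chloro in place of fluoro on an aromatic carbon. Compound 4 `CN(c1cc2ncc(=O)[nH]c2cc1NC(=N)NCc1ccc(OC(F)(F)F)cc1)C1CCCCC1` differs from compound 3 in one place: trifluoromethoxy in place of chloro on an aromatic carbon. Going by the values given here, no measured step covers an exchange of chloro for trifluoromethoxy, so the step from compound 2 to compound 3 is the only guide, and it was modest. A downward step of similar or smaller size, a 1.3-fold lower number from compound 3 to compound 4 (0.10 log units; within the scatter), is therefore expected for compound 4. Compound 4 is estimated at 3500 nM, within a range from 1500 nM to 8000 nM.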

Compound 4, half-maximal inhibitory concentration: 3700 nM
Estimate against measurement, compound 4: 1.1-fold (0.02 log units) below; low and high end bracket the measured number.
By their numbers in this assay, from the lowest: compounds 4 and 3 (each within the scatter of the next); then compounds 2 and 1 (each within the scatter of the next).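

In this assay, a 1.2-fold lower number from compound 3 to compound 4 (0.08 log units; within the scatter) shows that trifluoromethoxy, with five heavy atoms against one for chloro, can occupy this aromatic carbon, para to a large group, without a change beyond the scatter. With a 2.8-fold lower number from compound 2 to compound 4 (0.44 log units; beyond the scatter), a second group now stands apart from fluoro beyond the scatter, so that separation is not confined to chloro. Nothing available explains these results. Still open, going by these compounds, is whether an amine, a carboxylic acid or a longer alkyl chain at this carbon would give numbers like those of compound 3 and compound 4.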